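Oxygen substituent variation across compounds 1 to 4

The compounds below may be only part of what the source reports. "The series", "measured", "known", "first", "only" and "open" are said of these compounds alone.

Measured so far in an assay on cells with melanin-concentrating hormone receptor 1 (Homo sapiens) as the target, read by radioligand binding; on this read-out higher numbers stand for weaker inhibition and lower numbers for stronger inhibition:
- compound 1 `COCCOCCOc1cccc2ccc(N)nc12`: the assay reports only a limit for compound 1, > 2000 nM.
- compound 2 `CC(C)Oc1cccc2ccc(N)nc12`: 437 nM.
- compound 3 `CC1CCC(Oc2cccc3ccc(N)nc23)C1`: 823 nM.
- compound 4 `CCC(C)COc1cccc2ccc(N)nc12`: not yet measured.

Compound 3 and compound 2 sit within the scatter of each other; the only other entry, for compound 1, is a limit rather than a number (the limit of > 2000 nM in this assay, at which 1 of the 3 values shown sits). Going by the values given here, the one measured step on this oxygen, a 1.9-fold higher number from compound 2 to compound 3 (0.27 log units; within the scatter), is within the scatter, so swapping a small branched chain for a small ring did not move the read-out beyond noise.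

Compound 4 is made from compound 3 by 2-methylbutyl in place of 3-methylcyclopentyl on an oxygen on an aromatic ring. The change again exchanges one small, uncharged hydrocarbon substituent for another of similar size, with no donor or acceptor added or removed. Among the compounds with values here, on the single relevant step, no movement beyond the scatter is expected, in either direction.

Compound 4 is therefore expected to give about 650 nM, with a range of 250 nM to 1700 nM, which amounts to an expected step of a 1.3-fold lower number from compound 3 to compound 4 (0.10 log units; within the scatter).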

Compound 4, half-maximal inhibitory concentration: 36 nM
For compound 4 the middle estimate is 18-fold (1.26 log units) above the measured one; the whole stated range lies above it.
By their numbers in this assay, from the lowest: compound 4; then compounds 2 and 3 (each within the scatter of the next). At a limit, above all of these: compound 1.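

On an oxygen on an aromatic ring, 2-methylbutyl stands apart from both other hydrocarbon substituents in this assay, with a 23-fold lower number from compound 3 to compound 4 (1.36 log units; beyond the scatter) and a 12-fold lower number from compound 2 to compound 4 (1.08 log units; beyond the scatter). Uncharged hydrocarbon substituents without donors or acceptors are therefore not interchangeable at this place, and the absence of a ring does not separate them on its own, since compound 2 also has no ring and stays within the scatter of compound 3. The step of an at least 55-fold lower number from compound 1 to compound 4 (1.74 log units; beyond the scatter) starts from a limit, not a number: the limit of > 2000 nM in this assay, at which 1 of the 4 values shown sits.

Going by these compounds, whether the branch, its location on the chain or the chain length sets the value of compound 4 stays open. A straight pentyl chain, a longer chain and a chain ending in an amine would each address a part of this.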